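The compounds below may be only part of what the source reports. "The series", "measured", "known", "first", "only" and "open" are said of these compounds alone.

Working notes on the series. Compound 1 is `CC(C)(C)Cc1c(-c2cccnc2)sc(N)c1C(=O)c1ccc(Cl)cc1` and compound 2 is `COc1ccc(-c2sc(N)c(C(=O)c3ccc(Cl)c(Cl)c3)c2CC(C)(C)C)cc1`, both built on the shared core. In an assay on CHO cells for displacement of a labelled ligand from adenosine receptor A3 (Homo sapiens), read by scintillation counting, tested at 10 uM (on this read-out lower numbers stand for less inhibition and higher numbers for more inhibition at the one concentration tested (going by the name of the read-out)), compound 1 gives 1%. In this assay compound 2 gives 1%, so compound 1 stands level with compound 2 at the digits recorded, the two values lying within the scatter of each other. Neither compound shows appreciable displacement at the single concentration tested; both sit at the floor of the read-out.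

The unmeasured compound 3 is `CC(C)(C)Cc1c(-c2cccs2)sc(N)c1C(=O)c1ccc(Cl)cc1`. Relative to compound 1 the change is thiophen-2-yl in place of pyridin-3-yl on an aromatic carbon. Among the measured compounds shown here, no step between two measured compounds is available for an exchange of this kind, so the size of the step can only be judged from the low level of compound 1 in this assay and the equally low level of compound 2. Because compound 1 gives 1%, the step from the exchange is expected to be a number 3 percentage points higher from compound 1 to compound 3 (within the scatter), none beyond the scatter in either direction. Compound 3 is therefore estimated at 4% in this assay, with a range from -8% to 18%.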

Compound 3, a percentage reported as inhibition, at one concentration (the size of the read-out at that concentration, not a potency): 1%
Beside the measured number, compound 3's estimate is 3 percentage points above it; the measured number falls inside the stated range.
By their numbers in this assay, from the lowest: compounds 1, 2 and 3 (each within the scatter of the next).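

In this assay, thiophen-2-yl in place of pyridin-3-yl on the aromatic carbon next to the ring sulfur gives no change at the digits printed from compound 1 to compound 3 (within the scatter). Among the compounds shown here, this is the first direct reading at this position: a six-membered aromatic ring with a nitrogen and a five-membered aromatic ring with a sulfur leave the read-out at the same low level, so this exchange alone does not lift displacement off the floor. With both compounds at the floor, the step cannot show whether the group at this position matters for displacement, and no measurement offered here bears on the result.

Open, going by these compounds, is whether a group of a different kind on this carbon, such as a carboxylic acid or a longer chain ending in an amine, would raise the read-out above this level. Also open, on these data alone, is whether a change elsewhere on the shared core, such as a shorter chain in place of the neopentyl group or a free hydroxyl on the benzoyl ring, would give a signal against which changes at this position could be read.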